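Lengthening the methoxy of compound 3 to ethoxy

This account rests on a few compounds, and the source may have more. Where it says the series, first, only, none or still open, it means among the compounds named here.

In a functional assay on CCRF-CEM cells (Homo sapiens) for antiproliferative activity (a higher number here means a weaker inhibitor, a lower number a stronger inhibitor), compound 3 (`COc1ccc(-c2cc(N)c(C(=O)c3cc(OC)c(OC)c(OC)c3)s2)cc1`) gives 19 nM as the middle of three values. Compound 2 (`COc1cc(C(=O)c2sc(-c3cccc([N+](=O)[O-])c3)cc2N)cc(OC)c1OC`) gives 5.9 nM on the lower side and compound 1 (`COc1cc(C(=O)c2sc(-c3ccc(I)cc3)cc2N)cc(OC)c1OC`) gives 150 nM on the higher side. Compound 4 (`CCOc1ccc(-c2cc(N)c(C(=O)c3cc(OC)c(OC)c(OC)c3)s2)cc1`) departs from compound 3 by one change (methyl in place of hydrogen on a saturated chain carbon bound to an oxygen on an aromatic ring): methyl in place of hydrogen on a saturated chain carbon bound to an oxygen on an aromatic ring, turning 4-methoxyphenyl into 4-ethoxyphenyl. Two modest measured steps bear on this group: a 7.9-fold lower number from compound 1 to compound 3 (0.90 log units; beyond the scatter) and a 3.2-fold higher number from compound 2 to compound 3 (0.51 log units; beyond the scatter) as well. Neither merely lengthens a chain, so in this assay only a small step is expected, in no firm direction and possibly none beyond the scatter. For compound 4 the expected value is 22 nM within an estimated range of 8 nM to 60 nM as a working figure.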

Compound 4, half-maximal inhibitory concentration: 270 nM
For compound 4 the middle estimate is 12-fold (1.09 log units) below the measured one; the whole stated range lies below it.
By their numbers in this assay, from the lowest: compound 2; then compound 3; then compounds 1 and 4 (each within the scatter of the next).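

In this assay, one added methyl, turning methoxy into ethoxy, is enough for a large step, a 14-fold higher number from compound 3 to compound 4 (1.15 log units; beyond the scatter), so this position responds sharply to even this small lengthening. The change from 3-nitrophenyl to 4-ethoxyphenyl is also large, a 46-fold higher number from compound 2 to compound 4 (1.66 log units; beyond the scatter), whereas ethoxy in place of iodo gives a 1.8-fold higher number from compound 1 to compound 4 (0.26 log units; within the scatter), which leaves compound 1 and compound 4 within the scatter of each other. Nothing shown accounts for the effect of the added methyl. From the compounds shown here alone, whether a longer chain such as propoxy, or a hydroxy or an amine in place of the methoxy, would lie nearer compound 3 or compound 4 remains open.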